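The source may hold more compounds than are shown below. What is called first, only, known or untested is meant among the compounds shown, and "the series" means these compounds.

For the measured compounds named here, compound 2 `Cc1c(CC(=O)O)c2ccccc2n1Cc1ccc(O)c(C(C)C)c1` gives 450 nM in an assay on CV-1 cells for agonist activity at thyroid hormone receptor alpha (Homo sapiens), read by reporter gene assay, with a stated time of 10 h (a higher number here means that more compound is needed for the effect, a lower number that less compound is needed), the highest of the two numbers known so far; compound 1 `Cc1c(CCCCC(=O)O)c2ccccc2n1Cc1ccc(O)c(C(C)C)c1` gives 100 nM. Compound 3 `Cc1c(CCC(=O)O)c2ccccc2n1Cc1ccc(O)c(C(C)C)c1` differs from compound 2 by carboxymethyl in place of carboxy on a saturated chain carbon bound to an aromatic carbon. Going by the values given here, the only step that bears on this is the one in the same chain, where a longer chain went with a lower number: a 4.5-fold higher number from compound 1 to compound 2 (0.65 log units; beyond the scatter). A chain of intermediate length is therefore expected to bring a step downward of moderate size, a 2.3-fold lower number from compound 2 to compound 3 (0.35 log units; beyond the scatter). Compound 3 is estimated at 200 nM in this assay, with a likely range from 80 nM to 500 nM.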

Compound 3, half-maximal effective concentration: 39 nM
Estimate against measurement, compound 3: 5.1-fold (0.71 log units) above, and the stated range ends above it.
By their numbers in this assay, from the lowest: compound 3; then compound 1; then compound 2.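

The number in this assay does not fall steadily as the acid-bearing chain at this position lengthens: carboxymethyl in place of carboxy brings a 12-fold lower number from compound 2 to compound 3 (1.06 log units; beyond the scatter), while the shorter chain of compound 3 compared with compound 1 brings a 2.6-fold lower number from compound 1 to compound 3 (0.41 log units; beyond the scatter). Among these three compounds the lowest number therefore belongs to the chain of middle length, and compound 1, with the longest chain, goes against any steady trend with length. No measurement given here accounts for this turn. As far as these compounds go, it remains open how a still longer chain would behave, or an amide or a tetrazole in place of the carboxylic acid.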